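A few compounds are considered here, and "the series" means these few. Any claim that something is new, unique, unknown or untested is made for them only; others in the source may bear on it.

Of the compounds shown here, three with a shared core have been measured in a physicochemical assay, read by spectrophotometry, with a stated time of 30 min; on this read-out lower numbers stand for stronger inhibition and higher numbers for weaker inhibition. Compound 1 `O=C(CC(c1ccccc1)c1c[nH]c2ccccc12)c1c(O)c2ccccc2oc1=O`, which carries phenyl on a saturated chain carbon bound to an aromatic carbon and a saturated chain carbon, gives 12.4 ug/mL. Compound 2 `COc1ccc(OC)c(C(CC(=O)c2c(O)c3ccccc3oc2=O)c2c[nH]c3ccccc23)c1`, with 2,5-dimethoxyphenyl in place of phenyl, gives 19 ug/mL. Compound 3 `COc1ccc(C(CC(=O)c2c(O)c3ccccc3oc2=O)c2c[nH]c3ccccc23)cc1OC`, with 3,4-dimethoxyphenyl in place of phenyl, gives 63.2 ug/mL, the highest number of the set and so the weakest inhibition.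

Compound 4 `N#Cc1ccc(C(CC(=O)c2c(O)c3ccccc3oc2=O)c2c[nH]c3ccccc23)cc1` has 4-cyanophenyl in place of 3,4-dimethoxyphenyl at the same carbon: 4-cyanophenyl in place of 3,4-dimethoxyphenyl on a saturated chain carbon bound to an aromatic carbon and a saturated chain carbon. Going by the values given here, no measured compound carries a nitrile, so the evidence is indirect. Among the compounds with values here, three measured steps bear on the change. The swap from phenyl shows a 5.1-fold higher number from compound 1 to compound 3 (0.71 log units; beyond the scatter), the swap between the two dimethoxyphenyl groups shows a 3.3-fold higher number from compound 2 to compound 3 (0.52 log units; beyond the scatter), and the remaining step shows a 1.5-fold higher number from compound 1 to compound 2 (0.19 log units; within the scatter). Within the data shown here, compound 3 is thus the only compound set apart from the others, so leaving 3,4-dimethoxyphenyl behind is expected to lower the number in this assay by a modest amount. The expected change is a 2.5-fold lower number from compound 3 to compound 4 (0.40 log units; beyond the scatter). Compound 4 is estimated at 25 ug/mL, with an expected range from 9 ug/mL to 65 ug/mL.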

Compound 4, half-maximal inhibitory concentration: 13.7 ug/mL
For compound 4 the middle estimate is 1.8-fold (0.26 log units) above the measured one; the measured number falls inside the stated range.
By their numbers in this assay, from the lowest: compounds 1, 4 and 2 (each within the scatter of the next); then compound 3.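

In this assay the step to 4-cyanophenyl on the saturated chain carbon gives a 4.6-fold lower number from compound 3 to compound 4 (0.66 log units; beyond the scatter) and shows that a substituent on this phenyl ring need not bring the number up to that of compound 3. Cyano in place of hydrogen on an aromatic carbon gives a 1.1-fold higher number from compound 1 to compound 4 (0.04 log units; within the scatter) and the comparison with the 2,5-dimethoxyphenyl analogue gives a 1.4-fold lower number from compound 2 to compound 4 (0.14 log units; within the scatter) and so compound 1, compound 2 and compound 4 form one group, with compound 3 alone set apart by its 3,4-dimethoxyphenyl group. Nothing in the available data explains why this one group stands apart.

Going by these compounds, it remains open whether a single methoxy on the phenyl ring would stay with compound 1 or move toward compound 3, which would help show whether one methoxy or the particular pair is tied to the higher number. On these data alone, it is also open whether an amine or a carboxylic acid in place of the nitrile, or a longer chain in place of the whole aromatic group at this carbon, would stay with compound 4 or depart from it.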